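Swapping methyl for trifluoromethyl: an expectation for compound 3

The source may hold more compounds than are shown below. What is called first, only, known or untested is meant among the compounds shown, and "the series" means these compounds.

Compound 1 `COc1cc(OC)c2c(=O)cc(/C=C/c3ccc([N+](=O)[O-])cc3)oc2c1`: 9600 nM
Compound 2 `COc1ccc(/C=C/c2cc(=O)c3c(OC)cc(OC)cc3o2)cc1`: 17800 nM

Both compounds were tested in a functional assay on HeLa cells (Homo sapiens) for antiproliferative activity, read by MTT assay, with a stated time of 12 h; on this read-out lower numbers stand for stronger inhibition and higher numbers for weaker inhibition. Compound 1 gives 9600 nM and compound 2 gives 17800 nM. Going by the values given here, compound 2 holds the higher of the two numbers, but its only neighbour, compound 1, lies within the scatter, so the two cannot be told apart. Among the compounds with values here, the single exchange between them, a 1.9-fold higher number from compound 1 to compound 2 (0.27 log units; within the scatter), is the only measured step. Compound 3 `COc1cc(OC)c2c(=O)cc(/C=C/c3ccc(OC(F)(F)F)cc3)oc2c1` has not been measured. It differs from compound 2 by trifluoromethyl in place of methyl on an oxygen on an aromatic ring. The measured step concerns a different exchange and stayed within the scatter, and nothing is known here about a trifluoromethyl on an oxygen on an aromatic ring, so no step beyond the scatter is expected in this assay. Compound 3 is therefore expected to give about 15000 nM, between 5000 nM and 45000 nM. This expectation amounts to a step of a 1.2-fold lower number from compound 2 to compound 3 (0.07 log units; within the scatter).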

Compound 3, half-maximal inhibitory concentration: > 40000 nM
Compound 3: only a limit was reported; the forecaster's own chance of this, stated with the estimate: 10%; middle value at least 2.6-fold (0.42 log units) away from the limit.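

Unlike the exchange of nitro for methoxy, replacing methoxy with trifluoromethoxy on this aromatic carbon moves the result beyond the scatter in this assay, giving an at least 2.2-fold higher number from compound 2 to compound 3 (0.35 log units; beyond the scatter). The same holds for the exchange of nitro for trifluoromethoxy, which gives an at least 4.1-fold higher number from compound 1 to compound 3 (0.61 log units; beyond the scatter), so the identity of this group can matter for this read-out even though the first two compounds could not be told apart. The value of compound 3 is a limit, not a number: the limit of > 40000 nM in this assay, at which 1 of the 3 values shown sits.

The compounds shown do not tell how far compound 3 truly lies from compound 1 and compound 2, or why the number rises with this change. Going by these compounds, it also stays open whether an amine, a carboxylic acid or a longer chain such as ethoxy on this aromatic carbon would resemble compound 2 or compound 3.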